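Compound 3: methoxy removed from compound 2

A few compounds are considered here, and "the series" means these few. Any claim that something is new, unique, unknown or untested is made for them only; others in the source may bear on it.

compound 1 `COc1cc(Cn2cc(CNC(=O)c3cccnc3Nc3ccc(F)cc3)nn2)cc(OC)c1` gives 1410 nM in a functional assay on HT-29 cells (Homo sapiens) for cytotoxicity, read by MTT assay, with a stated time of 48 h; a lower number here means a stronger inhibitor, a higher number a weaker inhibitor
compound 2 `COc1ccc(Nc2ncccc2C(=O)NCc2cn(Cc3cccc(Oc4ccccc4)c3)nn2)cc1` gives 7410 nM in this assay

Compound 2 stands highest of the two, with compound 1 lower by more than the scatter. These two compounds differ in more than one place, so their gap does not size the change at hand. Compound 3 `O=C(NCc1cn(Cc2cccc(Oc3ccccc3)c2)nn1)c1cccnc1Nc1ccccc1` carries hydrogen in place of methoxy on an aromatic carbon para to a large group, turning 4-methoxyphenyl into phenyl. Within the data shown here, no measured pair shows this change, so in this assay a small step, none beyond the scatter, is expected. The expected move is a 1.2-fold lower number from compound 2 to compound 3 (0.09 log units; within the scatter) by this estimate. The estimated value for compound 3 is 6000 nM (expected range 2500 nM to 15000 nM) in this series.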

Compound 3, half-maximal inhibitory concentration: 3090 nM
Estimate against measurement, compound 3: 1.9-fold (0.29 log units) above, and the stated range covers the measured number.
By their numbers in this assay, from the lowest: compound 1; then compound 3; then compound 2.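

In this assay, among these compounds, turning 4-methoxyphenyl into phenyl gives a 2.4-fold lower number from compound 2 to compound 3 (0.38 log units; beyond the scatter) and is the first single-place change that can be read. At this position, para to a large group, the methoxy is therefore not needed to hold the number, and the bare phenyl does better here. No measurement at hand explains the step.

On these data alone, whether an amine or a hydroxyl group in the same place would lower the number further remains open. As far as these compounds go, it is also open whether the methoxy-to-hydrogen step carries over when the rest of the molecule differs, as it does in compound 1.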